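The compounds below may be only part of what the source reports. "The series", "measured", "known", "first", "only" and "open" are said of these compounds alone.

Working notes on the phenyl urea series in an ADME assay on the whole organism with Oryza sativa as the target, tested at 10 uM; a higher number here means a weaker effect of the compound at the concentration tested, a lower number a stronger effect.

Compound 1, `CCCCCc1ccc(NC(=O)N[C@H](C)c2ccccc2)cc1`, gives 97% in this assay. Compound 2, `CCCCCc1ccc(NC(=O)N[C@@H](C)c2ccccc2)cc1`, gives 93%, and compound 3, `CC(=O)c1ccccc1NC(=O)N[C@@H](C)c1ccccc1`, gives 96%; the three numbers sit within the scatter of one another, so compound 1 is not set apart from either. Within the data shown here, the one single-point step measured so far, a number 4 percentage points lower from compound 1 to compound 2 (within the scatter), is a step of configuration only, because of the fact that compounds 1 and 2 differ only in the configuration as drawn, and it leaves the read-out unchanged within the scatter.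

Compound 4, `C[C@@H](NC(=O)Nc1ccc(Br)cc1)c1ccccc1`, differs from compound 1 by bromo in place of pentyl on an aromatic carbon. Among the measured compounds shown here, no measured step exchanges one substituent for another on the aromatic ring; the step from compound 1 to compound 2 does not touch that position, and compound 3 differs from compound 1 in more than one place, so only the value of compound 3, 96%, can be set beside the others. With all three measured numbers close to one another and near the upper end of the read-out, no step beyond the scatter is expected for compound 4, and the step of a number 4 percentage points lower from compound 1 to compound 4 (within the scatter) is an estimate of near nothing. Compound 4 is therefore expected to give about 93% in this assay, in a range from 78% to 100%.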

Compound 4, a percentage reported as activity, at one concentration (the size of the read-out at that concentration, not a potency): 87%
Compound 4: middle estimate off by 6 percentage points, on the high side, within the range that was stated.
By their numbers in this assay, from the lowest: compounds 4, 2, 3 and 1 (each within the scatter of the next).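

Among these compounds, the exchange of pentyl for bromo on an aromatic carbon, para to a large group, is the first measured step at this position, and it gives a number 10 percentage points lower from compound 1 to compound 4 (within the scatter) in this assay. Replacing a chain of 5 carbons with a single bromine atom therefore does not take the read-out beyond the scatter, although this step is larger than the configurational step a number 4 percentage points lower from compound 1 to compound 2 (within the scatter). Nothing available accounts for the step from pentyl to bromo, as the only structural fact at hand concerns configuration and not this substituent.

As far as these compounds go, it remains open whether any group at this position can move the read-out beyond the scatter. An amine, a carboxylic acid or a longer chain in place of pentyl would test this, and a second substituent pair would show whether the step depends on the group that enters.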